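Working notes: selenium for sulfur in a cytotoxicity series

The source may report more compounds than this note shows. Statements on the series, on what has been measured and on what is new or still open speak of the compounds shown alone.

Measured compounds:
compound 1, `CS/C(=N\C(=O)c1cc2ccccc2s1)NC(=O)c1cc2ccccc2s1`, 98600 nM
compound 2, `O=C(/N=C(/NC(=O)c1cc(-c2ccccc2)nc2ccccc12)[Se]Cc1ccccc1)c1cc(-c2ccccc2)nc2ccccc12`, 88900 nM
compound 3, `CS/C(=N\C(=O)c1cc(-c2ccccc2)nc2ccccc12)NC(=O)c1cc(-c2ccccc2)nc2ccccc12`, > 100000 nM

In a functional assay on K562 cells (Homo sapiens) for cytotoxicity, read by MTT assay, with a stated time of 72 h (a lower number here means that less compound is tolerated, a higher number that more compound is tolerated), compound 1 gives 98600 nM and compound 2 gives 88900 nM; these two values lie within the scatter of each other. For compound 3 the assay reports only a limit, > 100000 nM, and not a number. The change from compound 3 to compound 2 is a group of 8 heavy atoms (7 carbon, 1 selenium; one six-membered aromatic ring of carbon only) in place of a group of 2 heavy atoms (1 carbon, 1 sulfur; no ring), on a carbon with a double bond to nitrogen and produced an at least 1.1-fold lower number from compound 3 to compound 2 (0.05 log units; that floor lies within the scatter); that the step is only a floor rests on (the limit of > 100000 nM in this assay, at which 1 of the 3 values shown sits). How the core of compound 1 differs from the core of compound 3 is not broken down here.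

Compound 4, `O=C(/N=C(/NC(=O)c1cc2ccccc2s1)[Se]Cc1ccccc1)c1cc2ccccc2s1`, is not yet measured. It differs from compound 1 by a group of 8 heavy atoms (7 carbon, 1 selenium; one six-membered aromatic ring of carbon only) in place of a group of 2 heavy atoms (1 carbon, 1 sulfur; no ring), on a carbon with a double bond to nitrogen, which is the same change as that from compound 3 to compound 2, made on the same kind of carbon. From compound 1 to compound 4 a step of a 1.2-fold lower number from compound 1 to compound 4 (0.09 log units; within the scatter) is expected, resting on the measured pair where the change gave an at least 1.1-fold lower number from compound 3 to compound 2 (0.05 log units; that floor lies within the scatter). Compound 4 is accordingly estimated at 80000 nM, expected to fall between 35000 nM and 150000 nM.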

Compound 4, concentration lethal to 50% of the cells: 70600 nM
Compound 4: middle estimate off by 1.1-fold (0.05 log units), on the high side; measured number inside the range.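

In this assay, placing the selenium-bearing group with its six-membered aromatic ring in place of methylsulfanyl, on a carbon with a double bond to nitrogen, gives a 1.4-fold lower number from compound 1 to compound 4 (0.15 log units; within the scatter). Set beside the earlier case, the two cores read as follows: the same change on two cores in this assay, an at least 1.1-fold lower number (0.05 log units; that floor lies within the scatter) from compound 3 to compound 2 and a 1.4-fold lower number (0.15 log units; within the scatter) from compound 1 to compound 4; the limit leaves it open whether they differ Neither core shows a change that clears the scatter, so these data do not establish that the change carries from one core to another, nor that it behaves differently on the two, and the earlier step rests on a limit of the assay and not on a number: the limit of > 100000 nM in this assay, at which 1 of the 4 values shown sits.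

The change swaps the sulfur for selenium and the methyl for a larger group in one step, so the compounds shown leave open what each part contributes; a methylselanyl or a benzylsulfanyl group on the same carbon would separate the two. Also open, from the compounds shown here alone, is how either core responds to a group of another kind at that carbon, such as an amine or a longer alkyl chain.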